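Swapping a Furan for a Methylphenyl: Tolerance in Mouse Macrophages

The compounds below may be only part of what the source reports. "The series", "measured", "known", "first", "only" and "open" are said of these compounds alone.

Of the compounds shown here, three built on a shared core have been tested in an ADME assay on J774.A1 cells (Mus musculus) for cytotoxicity, read by MTT assay, with a stated time of 72 h; a lower number here means that less compound is tolerated, a higher number that more compound is tolerated. Compound 1 `CC1(Cc2ccccc2)CC(S(=O)(=O)c2cccc(C(F)(F)F)c2)=C(c2ccc(/C(N)=N\O)cc2)O1` gives 14500 nM. Compound 3 `COc1ccc(C2(c3ccccc3)CC(S(=O)(=O)c3ccc(F)cc3)=C(c3ccc(/C(N)=N\O)cc3)O2)cc1` gives 11300 nM. Compound 2 `CC1(c2ccc(-c3ccco3)cc2)CC(S(=O)(=O)c2ccc(F)cc2)=C(c2ccc(/C(N)=N\O)cc2)O1` gives 4560 nM, the lowest of the three numbers; its gaps to compound 3 and to compound 1 both lie beyond the usual scatter, so compound 2 is the least tolerated of the three measured compounds.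

Compound 4 `Cc1ccc(-c2ccc(C3(C)CC(S(=O)(=O)c4ccc(F)cc4)=C(c4ccc(/C(N)=N\O)cc4)O3)cc2)cc1` has not yet been measured. It differs from compound 2 in one place: 4-methylphenyl in place of furan-2-yl on an aromatic carbon. For the measured compounds named here, no pair of measured compounds differs in exactly this way, so there is no measured step to lean on. The three measured values only show that changes elsewhere on the core move the number within a modest span, and nothing in them points to a large move for this particular exchange. The step that this estimate means is expected to be small, with no clear direction beyond the scatter: a 1.1-fold higher number from compound 2 to compound 4 (0.04 log units; within the scatter). Compound 4 is expected to give about 5000 nM in this assay, with a likely range from 2000 nM to 12500 nM.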

Compound 4, half-maximal cytotoxic concentration: 7910 nM
Compound 4: the middle estimate sits 1.6-fold (0.20 log units) below what was measured; low and high end bracket the measured number.
By their numbers in this assay, from the lowest: compounds 2, 4, 3 and 1 (each within the scatter of the next, the first and the last beyond it).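

For the compounds shown here, exchanging furan-2-yl for 4-methylphenyl, on an aromatic carbon para to a large group, gives the first directly measured step at this position: a 1.7-fold higher number from compound 2 to compound 4 (0.24 log units; within the scatter) in this assay. The earlier compounds shown here differed from one another in more than one place, so they could not isolate the effect of this position, whereas this pair differs only here. The group that leaves is a five-membered aromatic ring with one oxygen and the group that enters is a six-membered aromatic ring of carbon only with a methyl group, yet this clear change of ring produces a step no larger than the usual scatter, and no separate measurement bears on what lies behind the size of that step.

As far as these compounds go, a single exchange between two aromatic rings says little about how far this tolerance extends, so it remains open whether an amine, a carboxylic acid or a longer alkyl chain on the same aromatic carbon would give a step beyond the scatter. From the compounds shown here alone, it is also open whether the same exchange would give a similar step with a different group on the sulfonyl side of the shared core.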